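Sulfonamide Nitrogen Substituents in a Thiourea Series

A few compounds are considered here, and "the series" means these few. Any claim that something is new, unique, unknown or untested is made for them only; others in the source may bear on it.

Three thioureas sharing one core have been measured. Compound 1 `NS(=O)(=O)c1ccc(N/C(S)=N\c2ccnc3cc(C(F)(F)F)ccc23)cc1` carries a hydrogen on its sulfonamide nitrogen and gives 52900 nM in a functional assay on MDA-MB-231 cells (Homo sapiens) for antiproliferative activity, read by sulforhodamine B assay, with a stated time of 48 h; on this read-out higher numbers stand for weaker inhibition and lower numbers for stronger inhibition. Compound 2 `CC(=O)NS(=O)(=O)c1ccc(N/C(S)=N\c2ccnc3cc(C(F)(F)F)ccc23)cc1` carries an acetyl there and gives 58600 nM in this assay. Compound 3 `O=S(=O)(Nc1ncccn1)c1ccc(N/C(S)=N\c2ccnc3cc(C(F)(F)F)ccc23)cc1` carries a pyrimidin-2-yl and gives 45200 nM in this assay. Compound 2 stands together with the other two: the step of a 1.1-fold higher number from compound 1 to compound 2 (0.04 log units; within the scatter) and the step of a 1.3-fold lower number from compound 2 to compound 3 (0.11 log units; within the scatter) both lie within the scatter, as does the step of a 1.2-fold lower number from compound 1 to compound 3 (0.07 log units; within the scatter). Compound 4 `Cc1ccnc(NS(=O)(=O)c2ccc(N/C(S)=N\c3ccnc4cc(C(F)(F)F)ccc34)cc2)n1` has not yet been measured; it differs from compound 2 by 4-methylpyrimidin-2-yl in place of acetyl on a sulfonamide nitrogen. The step that bears most on this change is a 1.3-fold lower number from compound 2 to compound 3 (0.11 log units; within the scatter). The pyrimidin-2-yl of compound 3 is the closest measured relative of the 4-methylpyrimidin-2-yl of compound 4. Every exchange on that nitrogen so far has left the number within the scatter, so the expected step of a 1.2-fold lower number from compound 2 to compound 4 (0.09 log units; within the scatter) is also within the scatter. Compound 4 is therefore estimated at 48000 nM, with a range from 24000 nM to 96000 nM.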

Compound 4, half-maximal inhibitory concentration: 29800 nM
Compound 4: middle estimate off by 1.6-fold (0.21 log units), on the high side, and the stated range covers the measured number.
By their numbers in this assay, from the lowest: compounds 4, 3, 1 and 2 (each within the scatter of the next).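

Exchanging acetyl for 4-methylpyrimidin-2-yl on the sulfonamide nitrogen gives a 2.0-fold lower number from compound 2 to compound 4 (0.29 log units; within the scatter), the largest step on this nitrogen so far in this assay, and even this one stays inside the scatter. The same holds for the first change made on the pyrimidin-2-yl itself, methyl in place of hydrogen on an aromatic carbon, which gives a 1.5-fold lower number from compound 3 to compound 4 (0.18 log units; within the scatter), and for 4-methylpyrimidin-2-yl in place of hydrogen on the nitrogen, which gives a 1.8-fold lower number from compound 1 to compound 4 (0.25 log units; within the scatter). Among these compounds, all four compounds therefore still form a single group, with no printed step separating any two of them.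

On these data alone, it remains open whether a carboxylic acid, an amine or a longer alkyl chain on that nitrogen, or a methoxy in place of the methyl on the pyrimidin-2-yl, would give a step beyond the scatter. No measurement available here explains the numbers of these compounds.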